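Swapping Fluoro for Trifluoromethyl on a Piperazine Amide

The source may report more compounds than this note shows. Statements on the series, on what has been measured and on what is new or still open speak of the compounds shown alone.

Measured so far:
compound 1, `COCC(C(=O)N1CCN(c2cccc(C(F)(F)F)c2)CC1)N1C(=O)CCC1=O`, 50%
compound 2, `CCC(C(=O)N1CCN(c2cccc(F)c2)CC1)N1C(=O)CCC1=O`, 100%

Both compounds were tested in a functional assay on the whole organism (strain Swiss) with Mus musculus as the target, in the maximal electroshock model, with a stated time of 0.5 h, at a dose of 300 mg/kg by the intraperitoneal route; a higher number here means a stronger effect of the compound at the dose given, a lower number a weaker effect. Compound 2 stands at the top of the two numbers, and its nearest neighbour, compound 1, lies a step below it that is beyond the usual scatter. The unmeasured compound 3, `CCC(C(=O)N1CCN(c2cccc(C(F)(F)F)c2)CC1)N1C(=O)CCC1=O`, keeps the ethyl chain of compound 2 and changes only the aromatic ring: trifluoromethyl in place of fluoro on an aromatic carbon. Among the measured compounds shown here, no measured pair shows this exact change on its own, so its size is uncertain. Compound 1 also carries a trifluoromethyl on that ring, yet differs from compound 3 elsewhere, so its value is only a loose hint. A downward step of moderate size is expected from compound 2 to compound 3, a number 25 percentage points lower from compound 2 to compound 3 (beyond the scatter), partly because compound 1 with its trifluoromethyl gives 50%. Compound 3 is therefore estimated at 75%, within a range from 45% to 100%.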

Compound 3, a percentage reported as activity, at one dose (the size of the read-out at that dose, not a potency): 50%
Estimate against measurement, compound 3: 25 percentage points above; the range from low to high includes it.
By their numbers in this assay, from the lowest: compounds 1 and 3 (each within the scatter of the next); then compound 2.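

With the ethyl chain held fixed, the change of trifluoromethyl in place of fluoro in this assay gives a number 50 percentage points lower from compound 2 to compound 3 (beyond the scatter), so this aromatic carbon responds strongly to the swap at the dose given. On the chain, methyl in place of methoxy gives no change at the digits printed from compound 1 to compound 3 (within the scatter), which shows that with trifluoromethyl on the ring this chain change makes no visible difference to the read-out. Nothing shown here accounts for the large step on the ring.

On these data alone, each change is read only once and at a single dose, so it remains open whether the ring step would hold with the methoxy chain in place. As far as these compounds go, how a chloro or a nitrile at the same aromatic carbon, or a longer chain in place of the ethyl, would read also remains open.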